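The source may hold more compounds than are shown below. What is called first, only, known or untested is meant among the compounds shown, and "the series" means these compounds.

Among the measured compounds shown here, in a functional assay on A549 cells (Homo sapiens) for antiproliferative activity, read by sulforhodamine B assay, with a stated time of 48 h (on this read-out higher numbers stand for weaker inhibition and lower numbers for stronger inhibition), three compounds sharing one core have numbers so far. Compound 1 `COc1ccc(/C=C/C(=O)c2ccccc2-c2ccc(F)cc2)cc1` gives 140 nM, compound 2 `COc1cccc(/C=C/C(=O)c2ccccc2-c2ccc(F)cc2)c1OC` gives 7100 nM, and compound 3 `Cc1ccc(/C=C/C(=O)c2ccccc2-c2ccc(F)cc2)o1` gives 31000 nM, the highest of the three and so the weakest inhibition. Compound 4 `O=C(/C=C/c1cccs1)c1ccccc1-c1ccc(F)cc1` is still unmeasured. It differs from compound 3 in one place, on a double-bonded chain carbon bound to a double-bonded chain carbon, with thiophen-2-yl in place of 5-methylfuran-2-yl (thiophen-2-yl in place of 5-methylfuran-2-yl on a double-bonded chain carbon bound to a double-bonded chain carbon). For the measured compounds named here, one measured step bears on this place: a 220-fold higher number from compound 1 to compound 3 (2.35 log units; beyond the scatter), a large step that put 5-methylfuran-2-yl in place of 4-methoxyphenyl. Going by the values given here, it shows that the group here can move the number strongly, but no measured pair compares two five-membered rings, so its size cannot simply be carried over. The two groups in this change are much alike in what is counted, and compound 3 at 31000 nM already stands at the top of the numbers, so a modest move downward seems likeliest. The expected change is a 2.6-fold lower number from compound 3 to compound 4 (0.41 log units; beyond the scatter). For compound 4 the estimated value is 12000 nM, with an expected range from 2500 nM to 50000 nM.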

Compound 4, half-maximal inhibitory concentration: 12000 nM
For compound 4 middle estimate and measured number coincide at the digits printed; the range from low to high includes it.
By their numbers in this assay, from the lowest: compound 1; then compounds 2 and 4 (each within the scatter of the next); then compound 3.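

In this assay, among the compounds shown here, the first comparison of two five-membered aromatic rings at this place, on a double-bonded chain carbon bound to a double-bonded chain carbon, gives a 2.6-fold lower number from compound 3 to compound 4 (0.41 log units; beyond the scatter) and so shows that exchanging one such ring for the other still moves the number, though far less than leaving the 4-methoxyphenyl group did. Thiophen-2-yl in place of that group gives an 86-fold higher number from compound 1 to compound 4 (1.93 log units; beyond the scatter) so this second five-membered ring also stands far from compound 1, and the exchange between the two rings closes only a small part of that gap. Nothing measured here explains these differences.

Thiophen-2-yl differs from 5-methylfuran-2-yl both in its ring hetero atom and in lacking the methyl group, and the compounds shown do not separate these two changes. Going by these compounds, how a 4-aminophenyl group would fare at this place also remains open.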